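This account rests on a few compounds, and the source may have more. Where it says the series, first, only, none or still open, it means among the compounds named here.

Working notes on a three-membered set built on one shared core, all read in a functional assay on PC-12 cells (Rattus norvegicus) for cytotoxicity, read by MTT assay, with stated times of 2 h and 24 h, tested at 10 uM; on this read-out lower numbers stand for a weaker effect and higher numbers for a stronger effect at the one concentration tested. Compound 1 `Cc1ccc(-n2nc(-c3ccc(C(F)(F)F)cc3O)nc2-c2ccccc2O)cc1` gives 102%. Compound 2 `Oc1cc(C(F)(F)F)ccc1-c1nc(-c2ccccc2O)n(-c2ccc(Cl)cc2)n1` gives 96.1%. Compound 3 `Oc1cc(C(F)(F)F)ccc1-c1nc(-c2ccccc2O)n(-c2ccc(C(F)(F)F)cc2)n1` gives 102% in this assay. On these numbers compound 3 is level with compound 1 at the digits printed, the two together at the top of the set; its nearest neighbour is compound 1 with no change, its furthest compound 2, a number lower but within the scatter. The three measured steps, a number 5.9 percentage points lower from compound 1 to compound 2 (within the scatter), no change at the digits printed from compound 1 to compound 3 (within the scatter) and a number 5.9 percentage points higher from compound 2 to compound 3 (within the scatter), all swap one group on an aromatic carbon of the ring that sits on the aromatic nitrogen of the core, and none of them moves this assay beyond its scatter.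

Compound 4 `Oc1cc(C(F)(F)F)ccc1-c1nc(-c2ccccc2O)n(-c2ccccc2F)n1` is the next member. Its difference from compound 3 is 2-fluorophenyl in place of 4-(trifluoromethyl)phenyl on an aromatic nitrogen. The measured steps bear on it only loosely: they exchange groups on that same ring, whereas here the whole ring is exchanged, yet all three were within the scatter. Because no change at the digits printed from compound 1 to compound 3 (within the scatter) and a number 5.9 percentage points higher from compound 2 to compound 3 (within the scatter) show nothing beyond the scatter, the expected step of a number 3 percentage points lower from compound 3 to compound 4 (within the scatter) is likewise none beyond it. Compound 4 is therefore estimated at 99%, within 86% to 110%.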

Compound 4, a percentage reported as activity, at one concentration (the size of the read-out at that concentration, not a potency): 100%
Compound 4: middle estimate off by 1 percentage points, on the low side, within the range that was stated.
By their numbers in this assay, from the lowest: compounds 2, 4, 1 and 3 (each within the scatter of the next).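

In this assay, replacing the whole ring on the aromatic nitrogen with 2-fluorophenyl gives a number 2 percentage points lower from compound 3 to compound 4 (within the scatter), a number 3.9 percentage points higher from compound 2 to compound 4 (within the scatter) and a number 2 percentage points lower from compound 1 to compound 4 (within the scatter). The earlier steps shown here covered only 4-methylphenyl, 4-chlorophenyl and 4-(trifluoromethyl)phenyl at this position; these three steps add a 2-fluorophenyl group, with fewer heavy atoms than the 4-(trifluoromethyl)phenyl group it replaces, and none of them moves the read-out beyond the scatter. Nothing available explains this flat result.

The compounds shown leave open whether this position stays as flat with a ring carrying an amine or a carboxylic acid, or with a longer alkyl chain in place of the ring. All four compounds also keep the 2-hydroxyphenyl and 2-hydroxy-4-(trifluoromethyl)phenyl groups on the shared core, so these data give no reading of a methoxy group in place of either hydroxy group.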